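Nitro for fluoro on the benzyl arm of compound 3

A few compounds are considered here, and "the series" means these few. Any claim that something is new, unique, unknown or untested is made for them only; others in the source may bear on it.

Compound 3 `O=c1ccoc2cc(OCc3cn(Cc4cccc(F)c4)nn3)ccc12` is known only as a limit in a functional assay on A549 cells (Homo sapiens) for cytotoxicity, read by MTT assay, with a stated time of 48 h (a lower number here means a stronger inhibitor, a higher number a weaker inhibitor), where compound 3 gives > 100000 nM. Compound 1 `O=c1ccoc2cc(OCc3cn(Cc4cccc(Br)c4)nn3)ccc12` likewise sits at a limit, giving > 100000 nM in this assay. Compound 2 `Cc1ccccc1Cn1cc(COc2ccc3c(=O)ccoc3c2)nn1` also gives only a limit, > 100000 nM, in this assay. Because all three rest at the limit of > 100000 nM in this assay, at which 3 of the 3 values shown sit, the steps a step that the two limits leave unreadable from compound 1 to compound 2, a step that the two limits leave unreadable from compound 1 to compound 3 and a step that the two limits leave unreadable from compound 2 to compound 3 cannot be read in size or direction. Compound 4 `O=c1ccoc2cc(OCc3cn(Cc4cccc([N+](=O)[O-])c4)nn3)ccc12` differs from compound 3 by nitro in place of fluoro on an aromatic carbon. Within the data shown here, no measured step bears on this change beyond the shared limit, so no shift beyond the scatter can be anticipated. Compound 4 is therefore expected to give 100000 nM, with a range from 20000 nM to 500000 nM, in this assay. The expected step of a number no higher from compound 3 to compound 4 (the limit leaves the size open) is estimated to lie within the scatter.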

Compound 4, half-maximal inhibitory concentration: 9450 nM
The estimate for compound 4 lay 11-fold (1.02 log units) above the measured number; the whole stated range lies above it.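

In this assay, the 3-nitrophenyl arm gives the series its first number clear of the limit: nitro in place of fluoro gives an at least 10-fold lower number from compound 3 to compound 4 (1.02 log units; beyond the scatter), and nitro in place of bromo gives an at least 10-fold lower number from compound 1 to compound 4 (1.02 log units; beyond the scatter). The change from the 2-methylphenyl arm gives an at least 10-fold lower number from compound 2 to compound 4 (1.02 log units; beyond the scatter). The steps among compound 1, compound 2 and compound 3 remain unreadable: the limit of > 100000 nM in this assay, at which 3 of the 4 values shown sit.

From the compounds shown here alone, whether this step is particular to nitro stays open, as no other group, such as an amine or a nitrile, stands at this place. Nothing shown tells how nitro placed elsewhere on the ring would read.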